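This account rests on a few compounds, and the source may have more. Where it says the series, first, only, none or still open, it means among the compounds named here.

Compound 1 `COc1ccc(-c2ccc([C@@H](c3ccccc3)[C@@](O)(CCN(C)C)c3cccc4ccccc34)c(OC)n2)cc1` — > 50 ug/mL
Compound 2 `COc1nc(-c2ccc(C#N)cc2)ccc1[C@@H](c1ccccc1)[C@@](O)(CCN(C)C)c1cccc2ccccc12` — > 50 ug/mL

In a toxicity assay on Vero cells (Chlorocebus sabaeus) for cytotoxicity (on this read-out higher numbers stand for lower toxicity in this test and lower numbers for higher toxicity in this test), compound 1 gives > 50 ug/mL, which is a limit of the assay rather than a number. In this assay compound 2 gives > 50 ug/mL, likewise a limit and not a number. The step that the two limits leave unreadable from compound 1 to compound 2 therefore cannot be read in size, since both values sit at the limit of > 50 ug/mL in this assay, at which 2 of the 2 values shown sit. Compound 2 thus stands at a limit of this assay, with no measured number beneath it.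

Compound 3 `COc1nc(-c2ccccc2Cl)ccc1[C@@H](c1ccccc1)[C@@](O)(CCN(C)C)c1cccc2ccccc12` differs from compound 2 by 2-chlorophenyl in place of 4-cyanophenyl on an aromatic carbon. Going by the values given here, the only measured step that bears on this change is the one from compound 1 to compound 2, and its size is not readable. No step beyond the scatter is therefore expected in this assay. Compound 3 is expected to give 55 ug/mL in this assay, within a range from 25 ug/mL to 120 ug/mL. This amounts to an expected step that the limit leaves unreadable from compound 2 to compound 3 in this assay.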

Compound 3, half-maximal cytotoxic concentration: > 50 ug/mL
Compound 3 gave a limit, no number; the forecaster's own chance of this, stated with the estimate: 80%; the middle value is on the limit's open side.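

In this assay compound 3 gives > 50 ug/mL as a limit of the assay and not a number. Going by these compounds alone, no step among compound 1, compound 2 and compound 3 can be read in size. The compounds shown leave open whether 4-methoxyphenyl, 4-cyanophenyl and 2-chlorophenyl differ at all on this read-out.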